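The source may hold more compounds than are shown below. What is called first, only, known or untested is meant among the compounds shown, and "the series" means these compounds.

In a functional assay on HeLa cells (Homo sapiens) for antiproliferative activity, read by MTT assay, with a stated time of 48 h (a higher number here means a weaker inhibitor, a lower number a stronger inhibitor), compound 2 `Cn1cc(-c2cnc3ccnc(NCC4CC4)c3c2)cn1` gives 7400 nM and compound 3 `Cn1cc(-c2cnc3ccnc(NCc4ccc(F)cc4)c3c2)cn1` gives 9200 nM. With a 1.2-fold higher number from compound 2 to compound 3 (0.09 log units; within the scatter), these two stand level. Compound 1 `CC(=O)Nc1nccc2ncc(-c3cnn(C)c3)cc12`, with acetyl on that nitrogen, reads > 50000 nM, which is a limit and not a number. Replacing acetyl gives an at least 6.7-fold lower number from compound 1 to compound 2 (0.82 log units; beyond the scatter) and an at least 5.4-fold lower number from compound 1 to compound 3 (0.73 log units; beyond the scatter), both beyond the scatter. Compound 4 `Cn1cc(-c2cnc3ccnc(NS(=O)(=O)c4cccs4)c3c2)cn1` has (thiophen-2-yl)sulfonyl in place of 4-fluorobenzyl on a nitrogen on an aromatic ring. Among the compounds with values here, no measured compound carries a sulfonyl group, and acetyl in compound 1 is the nearest match, so part of an at least 5.4-fold lower number from compound 1 to compound 3 (0.73 log units; beyond the scatter) is expected to reverse. The expected change is a 2.7-fold higher number from compound 3 to compound 4 (0.43 log units; beyond the scatter), towards a higher number. Compound 4 is estimated at 25000 nM, with a range of 8000 nM to 70000 nM.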

Compound 4, half-maximal inhibitory concentration: 17400 nM
For compound 4 the middle estimate is 1.4-fold (0.16 log units) above the measured one, and the stated range covers the measured number.
By their numbers in this assay, from the lowest: compounds 2, 3 and 4 (each within the scatter of the next, the first and the last beyond it). At a limit, above all of these: compound 1.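

With a 1.9-fold higher number from compound 3 to compound 4 (0.28 log units; within the scatter), (thiophen-2-yl)sulfonyl and 4-fluorobenzyl stand level on this nitrogen, although the first brings hydrogen-bond acceptors and the second has none. Against cyclopropylmethyl the same group does register, with a 2.4-fold higher number from compound 2 to compound 4 (0.37 log units; beyond the scatter). It also does not read like acetyl, with an at least 2.8-fold lower number from compound 1 to compound 4 (0.45 log units; beyond the scatter), and that step rests on a limit, not a number: the limit of > 50000 nM in this assay, at which 1 of the 4 values shown sits.

The compounds shown leave open which part of (thiophen-2-yl)sulfonyl sets this reading, something a phenylsulfonyl or methylsulfonyl group could separate. They also leave open how the free amine, with no group on this nitrogen, would read.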